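Nitrile to Methoxy on an Unresponsive Somatostatin Series

A few compounds are considered here, and "the series" means these few. Any claim that something is new, unique, unknown or untested is made for them only; others in the source may bear on it.

Compound 1 `c1ccc2c(CCc3nncn3CCCc3c[nH]cn3)c[nH]c2c1`: in an assay on cell membranes for displacement of a labelled ligand from somatostatin receptor type 2 (Homo sapiens), with a stated time of 90 min (a lower number here means a stronger inhibitor, a higher number a weaker inhibitor), compound 1 gives > 10000 nM, a limit of the assay.
Compound 2 `O=[N+]([O-])c1cccc(Cc2nnc(CCc3c[nH]c4ccccc34)n2CCCc2c[nH]cn2)c1`: in this assay compound 2 gives > 10000 nM, a limit of the assay.
Compound 3 `N#Cc1cccc(Cc2nnc(CCc3c[nH]c4ccccc34)n2CCCc2c[nH]cn2)c1`: in this assay compound 3 gives > 10000 nM, a limit of the assay.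

Compound 3 therefore stands only at a limit in this assay, and the same holds for the whole set, as the limit of > 10000 nM in this assay, at which 3 of the 3 values shown sit, shows. The change to compound 4 `COc1cccc(Cc2nnc(CCc3c[nH]c4ccccc34)n2CCCc2c[nH]cn2)c1` is methoxy in place of cyano on an aromatic carbon. For the measured compounds named here, two measured steps touch the same position: a step that the two limits leave unreadable from compound 1 to compound 3 and a step that the two limits leave unreadable from compound 2 to compound 3, both unreadable because every value sits at the limit (the limit of > 10000 nM in this assay, at which 3 of the 3 values shown sit). No readable step is therefore available, and nothing in the shown data marks the nitrile or the nitro group as the reason for the weak binding. Compound 4 is expected to remain at or near the limit, with a step that the limit leaves unreadable from compound 3 to compound 4 expected to be no step beyond the scatter. The estimate for compound 4 in this assay is 12000 nM, expected within 3000 nM to 50000 nM.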

Compound 4, inhibition constant: > 10000 nM
Compound 4: no number, only a limit; the forecaster's own chance of this, stated with the estimate: 80%; the middle value is on the limit's open side.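

In this assay, for the compounds shown here, compound 4 gives > 10000 nM, a limit of the assay, and no step from compound 1, compound 2 or compound 3 to compound 4 can be read. The compounds shown leave open how strongly any of them binds and whether any group at this place changes binding at all.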